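A few compounds are considered here, and "the series" means these few. Any claim that something is new, unique, unknown or untested is made for them only; others in the source may bear on it.

Measured so far in an assay on RPMI-8226 cells for antagonist activity at P2X purinoceptor 7 (Homo sapiens), read by calcium flux; a lower number here means a stronger inhibitor, a higher number a weaker inhibitor:
compound 2 `O=c1[nH]c2ccccc2n1CCCCCN1CCN(C(c2ccccc2)c2ccccc2)CC1` — 560 nM
compound 1 `Cc1ccc(S(=O)(=O)N2CCN(CCCn3c(=O)[nH]c4ccccc43)CC2)cc1` — > 10000 nM

Compound 1 gives only a limit in this assay, (the limit of > 10000 nM in this assay, at which 1 of the 2 values shown sits). Within the data shown here, compound 2 therefore stands as the only compound with a number in this assay; no step between the two can be sized. Compound 3 `Cc1ccc2ccn(CCCCN3CCN(C(c4ccccc4)c4ccccc4)CC3)c2c1` differs from compound 2 by a group of 10 heavy atoms (9 carbon, 1 nitrogen; one five-membered aromatic ring with 1 hetero atom, one six-membered aromatic ring of carbon only) in place of a group of 11 heavy atoms (8 carbon, 2 nitrogen, 1 oxygen; one five-membered aromatic ring with 2 hetero atoms, one six-membered aromatic ring of carbon only), on a saturated chain carbon, four bonds along the chain from an amine nitrogen in a ring. No measured step covers a change of this kind, so the expectation rests on the single number shown and the change itself. Compound 3 is expected to come out somewhat weaker than compound 2, an estimated 2.7-fold higher number from compound 2 to compound 3 (0.43 log units; beyond the scatter). The estimate for compound 3 in this assay is 1500 nM, with a range from 400 nM to 6000 nM.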

Compound 3, half-maximal inhibitory concentration: 6500 nM
Estimate against measurement, compound 3: 4.3-fold (0.64 log units) below; the measured number lies above the stated range.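

This position is sensitive to the group it carries: at the saturated chain carbon, four bonds along the chain from an amine nitrogen in a ring, the exchange gives a 12-fold higher number from compound 2 to compound 3 (1.06 log units; beyond the scatter) in this assay. The entering group has 0 hydrogen-bond donors and the leaving group has 1, but this count changes together with the other differences between the groups. Nothing available bears on the cause of this step.

Which difference between the two groups accounts for the step remains open. Also open, from the compounds shown here alone, is whether a longer chain or an added amine on the entering group would give a lower number.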